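Replacing pyrrolidin-1-yl with dipropylamino on the shared core

The source may hold more compounds than are shown below. What is called first, only, known or untested is meant among the compounds shown, and "the series" means these compounds.

Measured in a functional assay on MCF7 cells (Homo sapiens) for inhibition, read by sulforhodamine B assay; on this read-out lower numbers stand for stronger inhibition and higher numbers for weaker inhibition:
Compound 1 `Cc1ccc(NC2=CC(=O)c3c(nc4n3[C@H]3OC[C@@H](O)[C@H]3OC4)C2=O)cc1C`: 4950 nM
Compound 2 `O=C1C(N2CCCC2)=CC(=O)c2c1nc1n2[C@H]2OC[C@@H](O)[C@H]2OC1`: > 16000 nM (a limit)

Compound 2 has no exact number on this read-out, since its > 16000 nM is a limit of the assay. The next compound to be tested is compound 3 `CCCN(CCC)C1=CC(=O)c2c(nc3n2[C@H]2OC[C@@H](O)[C@H]2OC3)C1=O`, which carries dipropylamino in place of pyrrolidin-1-yl on a double-bonded ring carbon.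

Among the compounds with values here, only one measured step bears on this change: an at least 3.2-fold higher number from compound 1 to compound 2 (0.50 log units; beyond the scatter). It also exchanges the group on a double-bonded ring carbon, and it shows that the exchange can matter in this assay. However, it starts from an arylamino group, and its size is known only as a limit. Within the data shown here, no measured step compares two groups of the kind now being exchanged, so the data give no direction for this change.

The working expectation is therefore no shift beyond the scatter, with compound 3 remaining weak and possibly reaching the limit as well. The expected step is a number no higher from compound 2 to compound 3 (the limit leaves the size open). For compound 3 the estimated value is 16000 nM, with an expected range from 6000 nM to 40000 nM.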

Compound 3, half-maximal inhibitory concentration: > 16000 nM
Compound 3: only a limit was reported; the forecaster's own chance of this, stated with the estimate: 50%; the middle value lies on the limit itself.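

In this assay compound 3 gives > 16000 nM, which is a limit of the assay and not a number. With dipropylamino in place of (3,4-dimethylphenyl)amino on the double-bonded ring carbon, the shared core shows an at least 3.2-fold higher number from compound 1 to compound 3 (0.50 log units; beyond the scatter), so the move to a higher number at this position is not tied to the ring of pyrrolidin-1-yl: it also appears with a group that has no ring. Dipropylamino and pyrrolidin-1-yl cannot be ranked against each other, and the step between compound 2 and compound 3 cannot be read, because both values are limits: the limit of > 16000 nM in this assay, at which 2 of the 3 values shown sit.

The compounds shown leave open how far compound 2 and compound 3 actually lie from the limit, and whether they differ at all in this assay. They also leave open whether a plain phenylamino group or a secondary amine such as propylamino on the same carbon would give a number close to that of compound 1, 4950 nM.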